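Swapping the halogen pattern on a benzylidene arm

A few compounds are considered here, and "the series" means these few. Any claim that something is new, unique, unknown or untested is made for them only; others in the source may bear on it.

Compound 2 `C=CCn1c(=O)/c(=C\c2cccc(Cl)c2Cl)[nH]c(=O)/c1=C\c1ccccc1OC` is the more active of the two compounds measured in a functional assay on NCI-H1975 cells (Homo sapiens) for cytotoxicity, read by CCK-8 assay, with a stated time of 72 h; a lower number here means a stronger inhibitor, a higher number a weaker inhibitor: compound 2 gives 4500 nM, whereas compound 1 `C=CCn1c(=O)/c(=C\c2cccc(F)c2)[nH]c(=O)/c1=C\c1ccccc1OC` gives 25600 nM. For the measured compounds named here, the only change between them, a 5.7-fold lower number from compound 1 to compound 2 (0.76 log units; beyond the scatter), is the single step available so far.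

Compound 3 `C=CCn1c(=O)/c(=C\c2cc(Br)ccc2F)[nH]c(=O)/c1=C\c1ccccc1OC` keeps the shared core of compound 2 and changes only the substituent on the same arm: 5-bromo-2-fluorophenyl in place of 2,3-dichlorophenyl on a double-bonded chain carbon bound to an aromatic carbon. One halogenated phenyl ring thus replaces another with a different pattern of halogens. Going by the values given here, only the step from compound 1 to compound 2 bears on this, and it shows that the pattern of halogens on this ring can move the number in this assay considerably. Among the compounds with values here, no measured pair shows how a bromine and a fluorine in these positions compare with two chlorines, so the direction is uncertain. Compound 3 is therefore expected to stay near compound 2, with a step of a 1.6-fold higher number from compound 2 to compound 3 (0.19 log units; within the scatter), and an estimated value of 7000 nM within a range of 2500 nM to 25000 nM.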

Compound 3, half-maximal inhibitory concentration: "not active" (no number reported)
Compound 3: no number reported; there is nothing to compare the estimate with.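

For the compounds shown here, compound 3 is reported as "not active" in this assay with no number, so no step from compound 2 to compound 3 can be read. As far as these compounds go, how 5-bromo-2-fluorophenyl compares numerically with 2,3-dichlorophenyl on this arm stays open. Nothing shown accounts for this result.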